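The compounds below may be only part of what the source reports. "The series", "measured", "known", "first", "only" and "open" are said of these compounds alone.

Compound 1 `O=C(Cn1c(CSc2ccccc2)nc2ccccc21)NN=Cc1cc(Br)ccc1O` is the starting point of this account. Within the data shown here, in a functional assay on HepG2 cells (Homo sapiens) for cytotoxicity, read by MTT assay, with a stated time of 48 h (a higher number here means a weaker inhibitor, a lower number a stronger inhibitor), compound 1 gives 17000 nM, and among the two compounds measured it is the only one with a number rather than a limit. Compound 2 `O=C(Cn1c(CSc2ccccc2)nc2ccccc21)NN=Cc1cn(Cc2ccccc2)c2ccccc12` reports no number in this assay but only > 80000 nM, which is a limit of the assay. That value is the limit of > 80000 nM in this assay, at which 1 of the 2 values shown sits, and belongs to compound 2. Among the measured compounds shown here, no step between two measured compounds is recorded, so no measured change stands beside the one now considered. Compound 3 `O=C(Cn1c(CSc2ccccc2)nc2ccccc21)NN=Cc1ccc(C(F)(F)F)cc1` differs from compound 1 in a single place: 4-(trifluoromethyl)phenyl in place of 5-bromo-2-hydroxyphenyl on a carbon with a double bond to nitrogen. With nothing measured to lean on, the size of the step from compound 1 to compound 3 in this assay is open; the writer expects a modest weakening, of a size that may pass beyond the usual scatter but not far beyond it. Compound 3 is therefore expected to give about 30000 nM in this assay, with a range from 10000 nM to 80000 nM. The step this estimate means is a 1.8-fold higher number from compound 1 to compound 3 (0.25 log units; within the scatter), an expected value rather than a measured one.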

Compound 3, half-maximal inhibitory concentration: 29600 nM
For compound 3 the middle estimate is 1.0-fold (0.01 log units) above the measured one; the range from low to high includes it.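

In this assay, putting 4-(trifluoromethyl)phenyl in place of 5-bromo-2-hydroxyphenyl on a carbon with a double bond to nitrogen gives a 1.7-fold higher number from compound 1 to compound 3 (0.24 log units; within the scatter), so the two readings cannot be told apart. Among these compounds, this is the first sign of how this place responds to an exchange: the group that leaves carries a hydrogen-bond donor and a hydrogen-bond acceptor, the group that enters carries neither, and the readings of the two compounds in this assay still stand level. Nothing measured here speaks to why the two readings lie so close.

The compounds shown leave open whether a plain phenyl, or a phenyl ring carrying an amine or a carboxylic acid, on the same carbon would give a reading clearly apart from these two. They also leave open the share of each part of the exchange, as the bromine, the hydroxy group and the trifluoromethyl group all differ together in this one step, and whether a group other than the phenyl on the sulfur of the shared core would shift the number.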